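Replacing one Aromatic Ring in a Dibenzoylhydrazine Series

The source may hold more compounds than are shown below. What is called first, only, known or untested is meant among the compounds shown, and "the series" means these compounds.

The series is followed in an assay on cells for agonist activity at ecdysone receptor (Bombyx mori), read by a luciferase reporter, with a stated time of 24 h; a higher number here means that more compound is needed for the effect, a lower number that less compound is needed. Compound 1 `CC(C)(C)N(NC(=O)c1ccccc1)C(=O)c1ccccc1I` gives 105 nM. Among the measured compounds shown here, compound 2 `CC(C)(C)N(NC(=O)c1ccccc1Cl)C(=O)c1ccccc1Cl` gives 331 nM, which is the higher of the two numbers so far, and its gap to compound 1 lies beyond the scatter. Compound 3 `COc1cccc(C(=O)NN(C(=O)c2ccccc2Cl)C(C)(C)C)c1` has not yet been measured. It differs from compound 2 in one place: 3-methoxyphenyl in place of 2-chlorophenyl on a carbonyl carbon. For the measured compounds named here, the data contain no measured step between two compounds that differ in only one place, so the size of this move can only be guessed. Going by the values given here, a 2-chlorophenyl is removed and a 3-methoxyphenyl enters on the carbonyl carbon; the only comparison at hand is compound 1 against compound 2, and it concerns a different change. Compound 3 is therefore expected to come out near compound 2, with an estimated step of a 1.7-fold lower number from compound 2 to compound 3 (0.22 log units; within the scatter), in this assay, and an estimated value of 200 nM, within a range of 60 nM to 700 nM.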

Compound 3, half-maximal effective concentration: 52.5 nM
Compound 3: the middle estimate sits 3.8-fold (0.58 log units) above what was measured; the measured number lies below the stated range.
By their numbers in this assay, from the lowest: compounds 3 and 1 (each within the scatter of the next); then compound 2.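

In this assay the group on this carbonyl carbon, whose other neighbour is an amide-type nitrogen, turns out to matter: exchanging 2-chlorophenyl for 3-methoxyphenyl gives a 6.3-fold lower number from compound 2 to compound 3 (0.80 log units; beyond the scatter) and so provides the series' first measured single-place step. This one pair cannot separate the loss of 2-chlorophenyl from the gain of 3-methoxyphenyl, and the exchange also adds a hydrogen-bond acceptor to the count of the group. No measurement at hand accounts for the size of this step.

The compounds shown leave open how far the lower number depends on the methoxy group itself, and whether an ethoxy group or an amine on the same ring would give a similar step. They also leave open whether the step would hold with a different group on the other carbonyl carbon.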